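The source may report more compounds than this note shows. Statements on the series, on what has been measured and on what is new or still open speak of the compounds shown alone.

In a functional assay on U2OS cells for antagonist activity at proto-oncogene Wnt-3 (Homo sapiens), read by a luciferase reporter, with a stated time of 18 h (a higher number here means that more compound is needed for the effect, a lower number that less compound is needed), compound 2 `CC(C)(C)NC(=O)N1CCC[C@H]1C(=O)N1CCC(NS(=O)(=O)c2cc(S(=O)(=O)c3ccccc3)ccc2C(F)(F)F)CC1` gives 30 nM, the lowest of the two numbers in hand; the nearest is compound 1 `O=C(Cn1ccnc1)N1CCC(NS(=O)(=O)c2cc(S(=O)(=O)c3ccccc3)ccc2C(F)(F)F)CC1`, which gives 230 nM. Among the compounds with values here, the single measured step, a 7.7-fold lower number from compound 1 to compound 2 (0.88 log units; beyond the scatter), exchanged the whole group on the carbonyl carbon at once. Compound 3 `CN1CCC[C@H]1C(=O)N1CCC(NS(=O)(=O)c2cc(S(=O)(=O)c3ccccc3)ccc2C(F)(F)F)CC1` is not yet measured; it carries methyl in place of (tert-butyl)carbamoyl on an amine nitrogen in a ring, so the same difference read one bond further out is 1-methylpyrrolidin-2-yl in place of 1-((tert-butyl)carbamoyl)pyrrolidin-2-yl. Within the data shown here, no measured step isolates the substituent on that ring nitrogen, and a part of the gain in a 7.7-fold lower number from compound 1 to compound 2 (0.88 log units; beyond the scatter) may belong to the (tert-butyl)carbamoyl that now leaves, so a moderate move back toward the number of compound 1 is expected, a 3.3-fold higher number from compound 2 to compound 3 (0.52 log units; beyond the scatter). Compound 3 is estimated at 100 nM in this assay, with a range from 35 nM to 300 nM.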

Compound 3, half-maximal effective concentration: 230 nM
Estimate against measurement, compound 3: 2.3-fold (0.36 log units) below; low and high end bracket the measured number.
By their numbers in this assay, from the lowest: compound 2; then compounds 1 and 3 (each within the scatter of the next).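

In this assay, methyl in place of (tert-butyl)carbamoyl on the amine nitrogen in the ring gives a 7.7-fold higher number from compound 2 to compound 3 (0.88 log units; beyond the scatter), so this position alone carries a step beyond the scatter. With methyl on that nitrogen, replacing (1H-imidazol-1-yl)methyl with 1-methylpyrrolidin-2-yl on the carbonyl carbon gives no change at the digits printed from compound 1 to compound 3 (within the scatter), so among these compounds the lower number appears only with (tert-butyl)carbamoyl present. Nothing available explains the effect of this change.

From the compounds shown here alone, it remains open which part of (tert-butyl)carbamoyl matters: acetyl, methylcarbamoyl or isopropylcarbamoyl on the same nitrogen would separate the carbonyl, the amide hydrogen and the tert-butyl end. The compounds shown also leave open how the free secondary amine, with only hydrogen on that nitrogen, would compare.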